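A few compounds are considered here, and "the series" means these few. Any claim that something is new, unique, unknown or untested is made for them only; others in the source may bear on it.

Compound 1 `Oc1cccc(-c2cc(-c3ccc(C(F)(F)F)cc3)cc(-c3cccc(O)c3)n2)c1`: 2330 nM
Compound 2 `Oc1ccc(-c2cc(-c3cccc(C(F)(F)F)c3)cc(-c3cccc(O)c3)n2)cc1`: 2630 nM

In a functional assay on T47D cells (Homo sapiens) for inhibition (a lower number here means a stronger inhibitor, a higher number a weaker inhibitor), compound 2 gives 2630 nM, and compound 1 gives 2330 nM; the two numbers lie within the usual scatter of each other, so neither can be set apart from the other. Compound 3 `Oc1ccc(-c2cc(-c3ccc(C(F)(F)F)cc3)cc(-c3cccc(O)c3)n2)cc1` has not been measured. It differs from compound 2 by 4-(trifluoromethyl)phenyl in place of 3-(trifluoromethyl)phenyl on an aromatic carbon. Going by the values given here, no measured pair shows this change alone, and compound 1, which also carries the 4-(trifluoromethyl)phenyl group, gives a number within the scatter of compound 2. No step beyond the scatter is expected; the step from compound 2 to compound 3 is estimated at a 1.1-fold lower number from compound 2 to compound 3 (0.02 log units; within the scatter). Compound 3 is expected to give about 2500 nM, within 1000 nM to 6000 nM.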

Compound 3, half-maximal inhibitory concentration: 2870 nM
Compound 3: middle estimate off by 1.1-fold (0.06 log units), on the low side; the measured number falls inside the stated range.
By their numbers in this assay, from the lowest: compounds 1, 2 and 3 (each within the scatter of the next).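

In this assay, 4-(trifluoromethyl)phenyl in place of 3-(trifluoromethyl)phenyl, opposite the ring nitrogen, now has a direct reading on its own (a 1.1-fold higher number from compound 2 to compound 3 (0.04 log units; within the scatter)), and this change does not separate the two compounds. 4-hydroxyphenyl in place of 3-hydroxyphenyl, a change at another place on the shared core, likewise stays within the scatter (a 1.2-fold higher number from compound 1 to compound 3 (0.09 log units; within the scatter)). Nothing available explains either result. From the compounds shown here alone, whether a nitrile in place of trifluoromethyl, or an amine or a carboxylic acid in place of the hydroxyl, would set a compound apart stays open.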